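This account rests on a few compounds, and the source may have more. Where it says the series, first, only, none or still open, it means among the compounds named here.

Measured so far in a physicochemical assay for lipophilicity; on this read-out higher numbers stand for higher lipophilicity and lower numbers for lower lipophilicity:

Compound 1 `COc1cc(O)c(C(=O)/C=C/c2cc(OC)c(OC)c(OC)c2)cc1OC`: 3.5
Compound 2 `COc1ccc(C(=O)/C=C/c2ccc(OC)c(OC)c2)c(O)c1`: 3.53
Compound 3 `COc1ccc(O)c(C(=O)/C=C/c2c(OC)cccc2OC)c1`: 3.52

Compound 2 stands level with the other two. Its value lies within the usual scatter of both compound 3 and compound 1, so these numbers give no real order among the three compounds.

The next compound, compound 4 `COc1ccc(C(=O)/C=C/c2cc(OC)c(OC)c(OC)c2)c(O)c1`, differs from compound 2 in one place: methoxy in place of hydrogen on an aromatic carbon. This is methoxy in place of hydrogen on an aromatic carbon, ortho to a methoxy group, meta to a large group and meta to a methoxy group. Going by the values given here, no measured pair shows this single change on its own, so the evidence is indirect. Compound 2 carries fewer methoxy groups than compound 1, and compound 1 still gives 3.5, within the scatter of compound 2. A change beyond the scatter is therefore not expected in this assay, in either direction. The expected size of the change is a number 0.03 log units lower from compound 2 to compound 4 (within the scatter). For compound 4 the estimated value is 3.5, with an expected range from 3.2 to 3.8.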

Compound 4, partition coefficient: 3.49
The estimate for compound 4 lay 0.01 log units above the measured number; the range from low to high includes it.
By their numbers in this assay, from the lowest: compounds 4, 1, 3 and 2 (each within the scatter of the next).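

In this assay, going by these compounds alone, methoxy in place of hydrogen on an aromatic carbon, ortho to a methoxy group, gives a number 0.04 log units lower from compound 2 to compound 4 (within the scatter), a direct reading of this single change that the earlier compounds could not provide. The other single change, hydrogen in place of methoxy on an aromatic carbon, gives a number 0.01 log units lower from compound 1 to compound 4 (within the scatter), so neither step separates its two compounds on this read-out. No measurement shown here accounts for these two readings.

Methoxy and hydrogen are the only two groups compared at this position, so a single swap between them says nothing about how a quite different group would read there. As far as these compounds go, whether an amine, a carboxylic acid or a longer chain on this aromatic carbon would move the number beyond the scatter remains open.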